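Methyl on the free hydroxy of compound 2

The compounds below may be only part of what the source reports. "The series", "measured", "known", "first", "only" and "open" are said of these compounds alone.

In a functional assay on HeLa cells (Homo sapiens) for cytotoxicity, read by MTT assay, with a stated time of 24 h (on this read-out lower numbers stand for stronger inhibition and higher numbers for weaker inhibition), compound 1 (`C/C(=N\NC(=O)/C(C#N)=C/c1ccccc1)c1c(O)c2ccc(O)cc2oc1=O`) gives 15800 nM and compound 2 (`COc1cc(/C=C(\C#N)C(=O)N/N=C(\C)c2c(O)c3ccc(O)cc3oc2=O)ccc1O`) gives 10500 nM, two values within the usual scatter of each other. Compound 3 (`COc1ccc(/C=C(\C#N)C(=O)N/N=C(\C)c2c(O)c3ccc(O)cc3oc2=O)cc1OC`) differs from compound 2 by methyl in place of hydrogen on an oxygen on an aromatic ring, which turns hydroxy into methoxy. Within the data shown here, only one measured step bears on this (a 1.5-fold lower number from compound 1 to compound 2 (0.18 log units; within the scatter)). It put 4-hydroxy-3-methoxyphenyl in place of phenyl and stayed within the scatter. A change of one methyl is therefore expected to stay within the scatter too (a 1.1-fold higher number from compound 2 to compound 3 (0.06 log units; within the scatter)). The estimate for compound 3 is 12000 nM (range 6000 nM to 24000 nM).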

Compound 3, half-maximal inhibitory concentration: 13500 nM
Compound 3: the middle estimate sits 1.1-fold (0.05 log units) below what was measured, and the stated range covers the measured number.
By their numbers in this assay, from the lowest: compounds 2, 3 and 1 (each within the scatter of the next).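

In this assay, methyl in place of hydrogen on this oxygen, which turns hydroxy into methoxy, stays within the scatter (a 1.3-fold higher number from compound 2 to compound 3 (0.11 log units; within the scatter)). So the free hydroxy of compound 2 is not needed to hold the number at this level. The 3,4-dimethoxyphenyl group also stays within the scatter of plain phenyl (a 1.2-fold lower number from compound 1 to compound 3 (0.07 log units; within the scatter)), and no supporting data explain this flat result. Going by these compounds, what stays open is whether a longer chain on this oxygen, or an amine or a carboxylic acid on the ring instead, would move the number beyond the scatter.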